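Swapping the methoxyphenyl arm of compound 1 for a thiazole

The source may report more compounds than this note shows. Statements on the series, on what has been measured and on what is new or still open speak of the compounds shown alone.

Measured compounds:
- compound 1 `COc1ccc(Cn2nc(Nc3cc(C)[nH]n3)c3ccccc3c2=O)cc1`: 1200 nM
- compound 2 `CC(=O)Nc1ccc(Cn2nc(Nc3cc(C)[nH]n3)c3ccccc3c2=O)cc1`: 4200 nM
- compound 3 `Cc1ccc(-n2nc(Nc3cc[nH]n3)c3ccccc3c2=O)cc1`: "not determined" (no result reported)

In a functional assay on HCT-116 cells (Homo sapiens) for cytotoxicity, read by CellTiter-Glo, with a stated time of 5 days (a lower number here means a stronger inhibitor, a higher number a weaker inhibitor), compound 1 gives 1200 nM, the lowest of the two numbers reported. Its nearest neighbour is compound 2, and the step of a 3.5-fold higher number from compound 1 to compound 2 (0.54 log units; beyond the scatter) came from an acetamido in place of methoxy on an aromatic carbon. Compound 4 `Cc1cc(Nc2nn(Cc3csc(C)n3)c(=O)c3ccccc23)n[nH]1` has not been measured. It differs from compound 1 by 2-methyl-1,3-thiazol-4-yl in place of 4-methoxyphenyl on a saturated chain carbon bound to an aromatic nitrogen. For the measured compounds named here, no measured step exchanges this ring for another, so the step from compound 2 only shows that a change on this arm can shift the number modestly. The expected step of a 1.7-fold higher number from compound 1 to compound 4 (0.22 log units; within the scatter) is therefore a small weakening with wide uncertainty. Compound 4 is estimated at 2000 nM, within 600 nM to 7000 nM.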

Compound 4, half-maximal inhibitory concentration: 4180 nM
Estimate against measurement, compound 4: 2.1-fold (0.32 log units) below; the measured number falls inside the stated range.
By their numbers in this assay, from the lowest: compound 1; then compounds 4 and 2 (each within the scatter of the next).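

In this assay, for the compounds shown here, this is the first measured exchange of the whole ring on this arm, and it gives a 3.5-fold higher number from compound 1 to compound 4 (0.54 log units; beyond the scatter). The 2-methyl-1,3-thiazol-4-yl ring therefore keeps a measurable number but does not match the 4-methoxyphenyl ring, and compound 1 stays lowest among the measured compounds. Nothing shown explains this shift. Open, going by these compounds, is whether a plain phenyl or a pyridine ring on this arm would give a lower number. Also open, on these data alone, is what the methyl group on the thiazole contributes.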